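From a tert-butyl limit to a 2-fluorophenyl analogue

The source may hold more compounds than are shown below. What is called first, only, known or untested is meant among the compounds shown, and "the series" means these compounds.

Compound 1 `COc1cc2ncnc(Nc3ccc(NC(=O)c4ccc(C)cc4)cc3)c2cc1OC` gives 19000 nM
Compound 2 `COc1cc2ncnc(Nc3ccc(NC(=O)c4ccc(C(C)(C)C)cc4)cc3)c2cc1OC` gives > 100000 nM

In a functional assay on MCF7 cells (Homo sapiens) for inhibition, read by MTT assay (a higher number here means a weaker inhibitor, a lower number a stronger inhibitor), compound 2 gives > 100000 nM and this is a limit, not a number. Among the compounds with values here, the one measured step is an at least 5.2-fold higher number from compound 1 to compound 2 (0.72 log units; beyond the scatter), with tert-butyl in place of methyl on an aromatic carbon. Compound 3 `COc1cc2ncnc(Nc3ccc(NC(=O)c4ccccc4F)cc3)c2cc1OC` has not yet been measured. Its difference from compound 2 is 2-fluorophenyl in place of 4-(tert-butyl)phenyl on a carbonyl carbon, so 2-fluorophenyl stands in place of 4-(tert-butyl)phenyl on a carbonyl carbon. The measured step bears on this change only in part, as it too concerns the tert-butyl group. Within the data shown here, with that group gone, the reading is expected to return toward that of compound 1 at 19000 nM in this assay, although no measured step covers the 2-fluorophenyl group. A lower number is therefore expected, and the estimated step is an at least 5.0-fold lower number from compound 2 to compound 3 (0.69 log units; beyond the scatter) in this assay, a sizeable move beyond the scatter. For compound 3 the estimate is 20000 nM, with an expected range from 6000 nM to 70000 nM.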

Compound 3, half-maximal inhibitory concentration: 11000 nM
Estimate against measurement, compound 3: 1.8-fold (0.26 log units) above, within the range that was stated.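

In this assay, 2-fluorophenyl in place of 4-(tert-butyl)phenyl on the carbonyl carbon gives an at least 9.0-fold lower number from compound 2 to compound 3 (0.95 log units; beyond the scatter), so the loss seen with compound 2 does not extend to every substituted phenyl group at this position. Against 4-methylphenyl, the same position with 2-fluorophenyl gives a 1.7-fold lower number from compound 1 to compound 3 (0.24 log units; within the scatter), so compound 1 and compound 3 read alike in this assay and cannot be put in order, even though their substituents differ in both identity and printed name position. Compound 2 alone is held at a limit, so its steps give a bound and not a size: the limit of > 100000 nM in this assay, at which 1 of the 3 values shown sits.

With only these three groups on the carbonyl carbon, the compounds shown cannot separate the contribution of the fluorine from that of its position on the phenyl ring, nor say how far the drop with 4-(tert-butyl)phenyl depends on the branched chain itself. Going by these compounds, how an unsubstituted phenyl, a 4-ethylphenyl, or a phenyl ring bearing an amine or a carboxylic acid would read in this assay remains open, as does any change to the shared core.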